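Swapping a benzyl for a 4-cyanophenyl: what happens to cell toxicity

The source may report more compounds than this note shows. Statements on the series, on what has been measured and on what is new or still open speak of the compounds shown alone.

Two compounds have so far been measured in an ADME assay on HepG2 cells (Homo sapiens) for cytotoxicity, read by luminescence, CellTiter-Glo and ATP content, with a stated time of 72 h; on this read-out higher numbers stand for an effect only at larger amounts of compound and lower numbers for an effect already at smaller amounts:

Compound 1, `c1ccc(CCc2ccc3c(NCCCNCc4ccco4)ccnc3c2)cc1`, gives 16000 nM.
Compound 2, `COc1ccc(F)cc1CNCCCNc1ccnc2cc(Oc3cccc(N(C)C)c3)ccc12`, gives 3300 nM.

Compound 1 therefore stands at the highest of the two numbers, meaning its effect on the cells appears only at the larger amount. Compound 2 gives the lower number, and the gap between them is beyond the usual scatter of repeated measurements, so the two really do differ. No single-point comparison between compound 1 and compound 2 is available, since they differ in several places at once.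

Compound 3, `N#Cc1ccc(Cc2ccc3c(NCCCNCc4ccco4)ccnc3c2)cc1`, is not yet measured. It is built from compound 1 by one change: 4-cyanophenyl in place of benzyl on a saturated chain carbon bound to an aromatic carbon. For the measured compounds named here, no measured pair shows what such a change does here, so the expectation must stay modest, and a step of little or no size beyond the scatter seems most likely, with a slight lean toward a higher number. Compound 3 is expected to give about 18000 nM, within a range from 7000 nM to 45000 nM, which amounts to an estimated step of a 1.1-fold higher number from compound 1 to compound 3 (0.05 log units; within the scatter).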

Compound 3, half-maximal effective concentration: 7910 nM
Beside the measured number, compound 3's estimate is 2.3-fold (0.36 log units) above it, within the range that was stated.
By their numbers in this assay, from the lowest: compound 2; then compound 3; then compound 1.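

For the compounds shown here, this is the first pair that differs in only one place, so a change can be followed directly: in this assay, 4-cyanophenyl in place of benzyl on a saturated chain carbon bound to an aromatic carbon gives a 2.0-fold lower number from compound 1 to compound 3 (0.31 log units; beyond the scatter). The group at this place therefore affects the cell read-out, with the effect appearing at smaller amounts of compound, although the step is modest. No measurement available here explains the step.

Read one bond further out, the same difference is phenethyl to 4-cyanobenzyl, so this single pair cannot separate the contribution of the nitrile from that of the altered chain; a plain benzyl in place of the phenethyl of compound 1, or a 4-carboxyphenyl or 4-aminophenyl in place of the 4-cyanophenyl of compound 3, would help to pull those apart. As far as these compounds go, whether the same step would appear on a different compound, such as compound 2 with its other groups, also remains open.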